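The compounds below may be only part of what the source reports. "The series", "measured", "known", "first", "only" and "open" are said of these compounds alone.

Measured in a functional assay on cells (Panel NCI-60 (60 carcinoma cell lines), Homo sapiens); on this read-out lower numbers stand for stronger inhibition of growth and higher numbers for weaker inhibition of growth:
compound 1, `O=C1C=CC(O)(c2cc3cc(F)ccc3n2S(=O)(=O)c2ccccc2)C=C1`: 66 nM
compound 2, `COc1ccc(S(=O)(=O)n2c(C3(O)C=CC(=O)C=C3)cc3ccccc32)cc1`: 160 nM
compound 3, `O=C1C=CC(O)(c2cc3ccccc3n2S(=O)(=O)c2ccc(F)cc2)C=C1`: 230 nM

Compound 1 gives the lowest number of the three, and its gaps to compound 2 and compound 3 lie beyond the scatter. Compounds 1 and 3 have the same atoms joined differently; the difference between the two cores is not broken down here. From compound 3 to compound 2 the change is methoxy in place of fluoro on an aromatic carbon, and in this assay it gave a 1.4-fold lower number from compound 3 to compound 2 (0.16 log units; within the scatter).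

Compound 4, `COc1ccc2c(c1)cc(C1(O)C=CC(=O)C=C1)n2S(=O)(=O)c1ccccc1`, is not yet measured. It differs from compound 1 by methoxy in place of fluoro on an aromatic carbon. This is the same kind of change as before, not the same: there it sat on a six-membered aromatic ring of carbon only, para to a large group; here the ring is part of a fused or bridged system of two rings, meta to a fused ring, para to a fused ring.

For compound 4 the expected step is a 1.1-fold higher number from compound 1 to compound 4 (0.03 log units; within the scatter), small because the same kind of change gave only a 1.4-fold lower number from compound 3 to compound 2 (0.16 log units; within the scatter). Compound 4 is estimated at 70 nM, between 30 nM and 180 nM.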

Compound 4, concentration for 50% growth inhibition: 130 nM
Estimate against measurement, compound 4: 1.9-fold (0.27 log units) below, within the range that was stated.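

Methoxy in place of fluoro on the core of compound 1 gave a 2.0-fold higher number from compound 1 to compound 4 (0.29 log units; within the scatter) in this assay. Set beside the earlier step, the change does not carry over with a fixed size from one core to the other: the same change on two cores in this assay, a 1.4-fold lower number (0.16 log units; within the scatter) from compound 3 to compound 2 and a 2.0-fold higher number (0.29 log units; within the scatter) from compound 1 to compound 4, 2.8-fold (0.45 log units) apart, beyond the scatter of two such steps Each step alone lies within the scatter, and the two pairs also differ in which ring carries the change, so these data show that a value for this change cannot be transferred reliably within the series, but not what sets the gap between the two steps.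

The compounds shown leave open how other groups, such as an amine or a carboxylic acid, would behave at either place. They also leave open whether a third pair would side with either step.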